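Swapping a Fluorophenyl for a Naphthyl Group on the Amine

The compounds below may be only part of what the source reports. "The series", "measured", "known", "first", "only" and "open" are said of these compounds alone.

compound 1 `C=C1[C@@H](OC(C)=O)C[C@@H]2[C@](C)(COC=O)[C@H](OC(C)=O)CC[C@@]2(C)[C@@H]1C[C@@H](Nc1cccc(F)c1)C1=CCOC1=O` — a functional assay on KB cells (Homo sapiens) for cytotoxicity, read by sulforhodamine B assay; a higher number here means a weaker inhibitor, a lower number a stronger inhibitor: 28600 nM
compound 2 `C=C1[C@@H](OC(C)=O)C[C@@H]2[C@](C)(COC=O)[C@H](OC(C)=O)CC[C@@]2(C)[C@@H]1C/C=C1/C(=O)OC[C@H]1OC(C)=O` — this assay: 21600 nM
compound 3 `C=C1[C@@H](OC(C)=O)C[C@@H]2[C@](C)(CO[Si](C)(C)C(C)(C)C)[C@H](OC(C)=O)CC[C@@]2(C)[C@@H]1C[C@@H](Nc1cccc(F)c1)C1=CCOC1=O` — this assay: 4560 nM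

Among these three numbers, compound 1 gives the highest. Compound 2 lies within the usual scatter of it, while compound 3 sits clearly apart, a 6.3-fold lower number from compound 1 to compound 3 (0.80 log units; beyond the scatter). Compound 4 `C=C1[C@@H](OC(C)=O)C[C@@H]2[C@](C)(COC=O)[C@H](OC(C)=O)CC[C@@]2(C)[C@@H]1C[C@@H](Nc1cccc2ccccc12)C1=CCOC1=O` differs from compound 1 in one place: naphthalen-1-yl in place of 3-fluorophenyl on an amine nitrogen. Within the data shown here, no measured step touches this amine substituent; the only known step alters the group on an oxygen on a saturated carbon, so it offers no guide here. With nothing to lean on, the expectation for compound 4 is a change within or close to the scatter, a 1.4-fold lower number from compound 1 to compound 4 (0.16 log units; within the scatter), with no firm direction. Compound 4 is therefore estimated at 20000 nM, expected to range from 7000 nM to 60000 nM.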

Compound 4, half-maximal inhibitory concentration: 32300 nM
Beside the measured number, compound 4's estimate is 1.6-fold (0.21 log units) below it; the measured number falls inside the stated range.
By their numbers in this assay, from the lowest: compound 3; then compounds 2, 1 and 4 (each within the scatter of the next).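

In this assay, among these compounds, naphthalen-1-yl in place of 3-fluorophenyl on the amine nitrogen gives a 1.1-fold higher number from compound 1 to compound 4 (0.05 log units; within the scatter) and so gives the first reading at this position: here, a second aromatic ring in place of the fluorinated single ring leaves no difference that can be told from scatter. No supporting data on why this is so are available.

As far as these compounds go, whether a non-aromatic group such as cyclohexyl, or a phenyl ring carrying a carboxylic acid, would separate from compound 1 remains open. Also open, from the compounds shown here alone, is whether naphthalen-1-yl would read the same alongside the silicon-containing group of compound 3.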